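Methyl on the Aryl Ring and Vero Cell Cytotoxicity

The compounds below may be only part of what the source reports. "The series", "measured", "known", "first", "only" and "open" are said of these compounds alone.

compound 1 `CCOC(=O)C1=C(C)N(c2ccccc2)C(C)=C(C(=O)OCC)C1c1cn(-c2ccccc2)nc1-c1ccccc1`: > 10 ug/mL
compound 2 `CCOC(=O)C1=C(C)N(c2ccccc2C)C(C)=C(C(=O)OCC)C1c1cn(-c2ccccc2)nc1-c1ccccc1`: > 10 ug/mL

In an ADME assay on Vero cells (Chlorocebus sabaeus) for cytotoxicity (on this read-out lower numbers stand for stronger inhibition and higher numbers for weaker inhibition), compound 1 gives > 10 ug/mL, which is a limit of the assay and not a number. Compound 2 gives > 10 ug/mL, also a limit. Between them lies a step that the two limits leave unreadable from compound 1 to compound 2. Compound 3 `CCOC(=O)C1=C(C)N(c2cccc(C)c2)C(C)=C(C(=O)OCC)C1c1cn(-c2ccccc2)nc1-c1ccccc1` differs from compound 1 by methyl in place of hydrogen on an aromatic carbon. Among the compounds with values here, the only measured step that bears on this change, from compound 1 to compound 2, cannot be read in size, as both values sit at the limit of > 10 ug/mL in this assay, at which 2 of the 2 values shown sit. Compound 3 is therefore expected to show no step beyond the scatter, a step that the limit leaves unreadable from compound 1 to compound 3. Compound 3 is estimated at 15 ug/mL, within 8 ug/mL to 40 ug/mL.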

Compound 3, half-maximal inhibitory concentration: > 10 ug/mL
Compound 3: no number, only a limit; the forecaster's own chance of this, stated with the estimate: 80%; the middle value is on the limit's open side.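

No step among compound 1, compound 2 and compound 3 can be read in this assay, as each value is a limit and not a number: the limit of > 10 ug/mL in this assay, at which 3 of the 3 values shown sit.

The compounds shown leave open whether methyl in place of hydrogen on the aromatic carbon changes this read-out at all, and by how much.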